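The compounds below may be only part of what the source reports. "The series", "measured", "known", "first", "only" and "open" are said of these compounds alone.

Compound 1, `CN(C)c1ncc(C(=O)Nc2ccccn2)nc1Cl`: 158 nM
Compound 2, `Nc1nc(N2CCCCC2)c(Cl)nc1C(=O)Nc1ccccn1`: 103 nM
Compound 3, `Nc1nc(N)c(C(=O)Nc2ccccn2)nc1Cl`: 3800 nM

These three compounds were measured in an assay on Ltk cells for inhibition of metabotropic glutamate receptor 5 (Homo sapiens), read by fluorescence; on this read-out lower numbers stand for stronger inhibition and higher numbers for weaker inhibition. Compound 1 stands second highest of the three numbers. Its nearest neighbour is compound 2, whose number lies within the scatter of that of compound 1, so no order can be read between the two; its furthest is compound 3, whose number lies well beyond the scatter above it.

Compound 4, `O=C(Nc1ccccn1)c1cncc(Cl)n1`, has not yet been measured. It differs from compound 1 in one place: hydrogen in place of dimethylamino on an aromatic carbon. Going by the values given here, only one measured step bears on this change: a 37-fold higher number from compound 2 to compound 3 (1.57 log units; beyond the scatter). There a larger amine was replaced by a smaller one, and the number rose a great deal. Among the compounds with values here, the change from compound 1 to compound 4 removes the amine altogether rather than shrinking it, so the two steps are not of exactly the same kind, but the one comparison available points in a single direction. The account therefore expects a step in this assay toward a higher number, beyond the scatter, and probably large.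

Compound 4 is accordingly estimated at 1500 nM, within a range from 400 nM to 6000 nM, which corresponds to an expected step of a 9.5-fold higher number from compound 1 to compound 4 (0.98 log units; beyond the scatter).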

Compound 4, half-maximal inhibitory concentration: 254 nM
Estimate against measurement, compound 4: 5.9-fold (0.77 log units) above; measured number outside the range, below it.
By their numbers in this assay, from the lowest: compounds 2, 1 and 4 (each within the scatter of the next, the first and the last beyond it); then compound 3.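

In this assay, hydrogen in place of dimethylamino on this aromatic carbon, next to the ring nitrogen and ortho to a chloro group, gives a 1.6-fold higher number from compound 1 to compound 4 (0.21 log units; within the scatter), so no order can be read between the two compounds. Going by these compounds alone, on the core of compound 1, then, dimethylamino at this place can give way to hydrogen with the number staying within the scatter, something the only earlier step, a 37-fold higher number from compound 2 to compound 3 (1.57 log units; beyond the scatter), gave no sign of, and that large step does not carry over to this change. Nothing measured here speaks to why the loss of this group leaves the number within the scatter.

The compounds shown leave open whether a group other than dimethylamino at this place, such as methoxy or a longer chain like n-butyl, would move the number beyond the scatter in either direction on this core. They also leave open what the chloro group contributes, since no pair shown replaces it with, for instance, a nitrile or a methyl group.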